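Adding a Methyl Group to an Inactive Thiazole Amide

The source may report more compounds than this note shows. Statements on the series, on what has been measured and on what is new or still open speak of the compounds shown alone.

Measured so far:
compound 1, `CCOC(=O)c1sc(NC(=O)Cn2cc(-c3cccs3)nn2)nc1C`, 20 nM
compound 2, `Cc1csc(NC(=O)Cn2cc(-c3ccc(F)cc3)nn2)n1`, 250 nM
compound 3, `O=C(Cn1cc(-c2cccs2)nn1)Nc1nccs1`, > 30000 nM

All three compounds were tested in a functional assay on BMDM cells (Mus musculus, strain C57BL/6) for inhibition, with a stated time of 2 days; a higher number here means a weaker inhibitor, a lower number a stronger inhibitor. Compound 1 gives 20 nM and compound 2 gives 250 nM. Compound 3 is a different case: in this assay compound 3 reaches only the limit of the measurement and gives > 30000 nM, so no number is known for it, only that it lies at that limit (the limit of > 30000 nM in this assay, at which 1 of the 3 values shown sits).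

The next compound, compound 4, is `Cc1csc(NC(=O)Cn2cc(-c3cccs3)nn2)n1`. It differs from compound 3 in one place: methyl in place of hydrogen on an aromatic carbon. Among the measured compounds shown here, no measured pair with exactly this change exists among the three compounds, so the size of the step has to be judged from the neighbours. Compound 2 carries the same 4-methyl-1,3-thiazol-2-yl group with a different aromatic ring and gives 250 nM, and compound 1 carries the same thiophene with a further substituted thiazole and gives 20 nM.

On that basis compound 4 is expected to land well inside the measurable range, at roughly 200 nM, with a plausible span from 40 nM to 2000 nM. The expected step of an at least 150-fold lower number from compound 3 to compound 4 (2.17 log units; beyond the scatter) is thus a gain in potency far beyond the scatter, though its exact size cannot be fixed when compound 3 is known only as a limit.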

Compound 4, half-maximal inhibitory concentration: 40 nM
The estimate for compound 4 lay 5.0-fold (0.70 log units) above the measured number, and the stated range covers the measured number.
By their numbers in this assay, from the lowest: compounds 1 and 4 (each within the scatter of the next); then compound 2. At a limit, above all of these: compound 3.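

In this assay, the change from 1,3-thiazol-2-yl to 4-methyl-1,3-thiazol-2-yl gives an at least 750-fold lower number from compound 3 to compound 4 (2.87 log units; beyond the scatter), so a single methyl on this aromatic carbon separates a compound at the edge of the measurement from one with a clear, low value. With that methyl in place, the other two changes count for much less: replacing ethoxycarbonyl with hydrogen gives a 2.0-fold higher number from compound 1 to compound 4 (0.30 log units; within the scatter), so on these numbers the ethoxycarbonyl group is not needed for activity, and replacing 4-fluorophenyl with thiophen-2-yl gives a 6.3-fold lower number from compound 2 to compound 4 (0.80 log units; beyond the scatter), a real but far smaller change than the one the methyl brings. The true size of the methyl step stays unknown because compound 3 stands at a limit of the assay, so its step is only a bound: the limit of > 30000 nM in this assay, at which 1 of the 4 values shown sits.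

The compounds shown leave open whether an ethyl group or a chlorine atom on the same aromatic carbon would serve as well as methyl. They also leave open whether taking the methyl away from compound 2, with its 4-fluorophenyl group, would cost as much as it does in the thiophene series.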